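Does the mirror form of compound 2 hold its potency?

The source may report more compounds than this note shows. Statements on the series, on what has been measured and on what is new or still open speak of the compounds shown alone.

In a functional assay on HCT-8 cells (Homo sapiens) for cytotoxicity, read by sulforhodamine B assay (a higher number here means that more compound is needed for the effect, a lower number that less compound is needed), compound 1 (`COc1cccc(C2CC(=O)c3ccccc3N2)c1`), drawn without a configuration at its stereocentre, gives 0.12 ug/mL and compound 2 (`COc1cccc([C@@H]2CC(=O)c3ccccc3N2)c1`) gives 0.09 ug/mL for the same effect. Within the data shown here, these two values cannot be told apart: the only measured step is a 1.3-fold lower number from compound 1 to compound 2 (0.12 log units; within the scatter) and what separates the pair is the fact that one of compounds 1 and 2 is drawn with a defined configuration and the other without, at the place where they differ alone.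

Compound 3 (`COc1cccc([C@H]2CC(=O)c3ccccc3N2)c1`) changes one thing: the two compounds have the same atoms and bonds and differ only in configuration as drawn: 1 of 1 stereo elements differ; a stereocentre at a saturated ring carbon is drawn S in compound 2 and R in compound 3 and nothing leaves or enters. Among the measured compounds shown here, no measurement yet shows the R form on its own. Should compound 1 be an equal mixture of the S and R forms, the small size of a 1.3-fold lower number from compound 1 to compound 2 (0.12 log units; within the scatter) suggests that compound 3 keeps much of the effect, although a step this small settles little. A modest rise in the number is therefore expected, not a collapse. The estimated change is a 2.0-fold higher number from compound 2 to compound 3 (0.30 log units; within the scatter) in this assay as a working expectation. For compound 3 the expected value is 0.18 ug/mL with an estimated range from 0.07 ug/mL to 0.6 ug/mL until the measurement arrives.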

Compound 3, concentration for half-maximal effect: 0.5 ug/mL
Estimate against measurement, compound 3: 2.8-fold (0.44 log units) below; the measured number falls inside the stated range.
By their numbers in this assay, from the lowest: compounds 2 and 1 (each within the scatter of the next); then compound 3.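

In this assay the configuration at this stereocentre now shows a real effect, which the first pair could not reveal: the mirror-image pair gives a 5.6-fold higher number from compound 2 to compound 3 (0.74 log units; beyond the scatter), and the drawn configuration is the only structural difference to which this gap can be traced: the fact that compounds 2 and 3 differ only in the configuration as drawn. Compound 3 also separates from the compound drawn without a configuration, with a 4.2-fold higher number from compound 1 to compound 3 (0.62 log units; beyond the scatter), while compounds 1 and 2 remain within the scatter of each other: the fact that one of compounds 1 and 3 is drawn with a defined configuration and the other without, at the place where they differ. The R form therefore needs more compound than the S form for the same effect, but the step is modest and compound 3 still gives a measurable value of 0.5 ug/mL, so the change weakens the effect without abolishing it.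

From the compounds shown here alone, these compounds all carry the same methoxy group, so it remains open whether the preference for the S form would persist with a hydroxyl group or a fluorine atom in its place. Going by these compounds, the composition of compound 1 as a mixture of the two forms also remains unknown, as does whether the same gap between the mirror forms would appear on other cell types.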